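Shortening the selenium chain: what to expect for compound 4

This account rests on a few compounds, and the source may have more. Where it says the series, first, only, none or still open, it means among the compounds named here.

Measured compounds:
compound 1, `CCCCC[Se]c1nc(NCc2ccc(SC)cc2)c2ccccc2n1`: 57400 nM
compound 2, `CCCCC[Se]c1nc(NCc2ccccc2)c2ccccc2n1`: 70900 nM
compound 3, `CSc1nc(NCCCCCO)c2cccnc2n1`: a limit of the assay, > 100000 nM

In an ADME assay on 184B5 cells (Homo sapiens) for cytotoxicity, read by MTT assay, with a stated time of 72 h (on this read-out higher numbers stand for weaker inhibition of growth and lower numbers for stronger inhibition of growth), compound 1 gives 57400 nM, which is the lowest of the two plain numbers shown. Its nearest neighbour is compound 2, and the step of a 1.2-fold higher number from compound 1 to compound 2 (0.09 log units; within the scatter) stays within the scatter, so the two compounds cannot be told apart on this read-out. Compound 3 sits at the limit of > 100000 nM in this assay, at which 1 of the 3 values shown sits, and provides no number.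

Compound 4, `CSc1ccc(CNc2nc([Se]C)nc3ccccc23)cc1`, is compound 1 with a shorter chain on the selenium: hydrogen in place of butyl on a saturated chain carbon bound to a selenium atom. Within the data shown here, no measured step touches this part of the molecule. Among the measured compounds shown here, the only measured step, a 1.2-fold higher number from compound 1 to compound 2 (0.09 log units; within the scatter), changes the other end of compound 1 and is within the scatter, so there is no direct evidence on the chain at selenium. In this situation the expectation for compound 4 is a number close to that of compound 1, with room for a modest rise, and the step of a 1.4-fold higher number from compound 1 to compound 4 (0.14 log units; within the scatter) is what that estimate means. Compound 4 is therefore expected to give about 80000 nM in this assay, most likely between 30000 nM and 200000 nM, with a fair chance that only a limit is reported.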

Compound 4, concentration for 50% growth inhibition: 37100 nM
Estimate against measurement, compound 4: 2.2-fold (0.33 log units) above, and the stated range covers the measured number.
By their numbers in this assay, from the lowest: compounds 4, 1 and 2 (each within the scatter of the next). At a limit, above all of these: compound 3.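

In this assay, the change at the selenium end of the molecule, read as pentyl to methyl, gives a 1.5-fold lower number from compound 1 to compound 4 (0.19 log units; within the scatter). Among these compounds, this is the first measured step at this position, and it is a substantial cut to the chain: the butyl part leaves and a hydrogen takes its place, yet the two compounds cannot be told apart on this read-out, so on the core of compound 1 the full pentyl chain is not needed to keep the weak growth inhibition seen here. Nothing in the data on hand explains why the two compounds read alike.

On these data alone, it remains open whether this tolerance extends to other groups on selenium, such as a longer chain, a branched chain, or a chain ending in an amine or a carboxylic acid, since only pentyl and methyl appear at this position. Also open, as far as these compounds go, is whether a methyl group on selenium would read the same way with hydrogen in place of methylsulfanyl, or whether sulfur could stand in for selenium on an otherwise unchanged molecule.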